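Carbamate in place of acetamide on the aryl nitrogen

This account rests on a few compounds, and the source may have more. Where it says the series, first, only, none or still open, it means among the compounds named here.

The shared core of compound 1 `CC1(C)Oc2ccc(C#N)cc2[C@H](N(CC(=O)O)c2ccccc2)[C@H]1O` carries, on its aromatic nitrogen, a short chain that is varied across the set. In a functional assay (aorta) with Rattus norvegicus as the target (a higher number here means a weaker inhibitor, a lower number a stronger inhibitor), compound 1 gives > 100000 nM, which is a limit of the assay and not a number. Compound 2 `CCCCOC(=O)CN(c1ccccc1)[C@H]1c2cc(C#N)ccc2OC(C)(C)[C@@H]1O` gives 27000 nM in this assay, and the step of an at least 3.7-fold lower number from compound 1 to compound 2 (0.56 log units; beyond the scatter) is the only one in the set that is read as beyond the scatter. Compound 3 `CC(=O)NCCN(c1ccccc1)[C@H]1c2cc(C#N)ccc2OC(C)(C)[C@@H]1O` gives > 30000 nM in this assay, again a limit rather than a number. The step of an at least 1.1-fold higher number from compound 2 to compound 3 (0.04 log units; that floor lies within the scatter) and the step that the two limits leave unreadable from compound 1 to compound 3 leave compound 3 among the weaker members, with its position fixed only by the limits the limit of > 100000 nM in this assay, at which 1 of the 3 values shown sits, and (the limit of > 30000 nM in this assay, at which 1 of the 3 values shown sits).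

Compound 4 `CCOC(=O)NN(c1ccccc1)[C@H]1c2cc(C#N)ccc2OC(C)(C)[C@@H]1O` differs from compound 3 by (ethoxycarbonyl)amino in place of 2-acetamidoethyl on a nitrogen on an aromatic ring. Going by the values given here, no measured step changes the chain in this way; the step from compound 1 to compound 2 alters an ester on a different part of the chain, and the step from compound 2 to compound 3 swaps the whole chain. The nearest comparison is therefore the modest, scatter-level step from compound 2 to compound 3, so no change beyond the scatter is expected, and compound 4 is estimated at 40000 nM (between 10000 nM and 200000 nM), which corresponds to the expected step that the limit leaves unreadable from compound 3 to compound 4.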

Compound 4, half-maximal inhibitory concentration: 2200 nM
Compound 4: middle estimate off by 18-fold (1.26 log units), on the high side; the whole stated range lies above it.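

Setting (ethoxycarbonyl)amino in place of 2-acetamidoethyl on a nitrogen on an aromatic ring gives an at least 13-fold lower number from compound 3 to compound 4 (1.13 log units; beyond the scatter) in this assay, which shows that this position can respond strongly to a change of chain of the same heavy-atom count. The group also stands clear of the two other chains, with a 12-fold lower number from compound 2 to compound 4 (1.09 log units; beyond the scatter) against (butoxycarbonyl)methyl and an at least 45-fold lower number from compound 1 to compound 4 (1.65 log units; beyond the scatter) against carboxymethyl, so compound 4 is the most potent of the four compounds, its steps to all the others being beyond the scatter. The earlier compounds shown here all hold a chain joined to this nitrogen through carbon and showed only weak values, whereas compound 4, with a nitrogen joined there, shows that the shared core can reach a clearly lower number in this assay.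

Nothing shown gives a reason for this gain. From the compounds shown here alone, it remains open whether the gain belongs to the joined nitrogen or to the whole ethoxycarbonyl group, and whether an acetylamino group, a butoxycarbonylamino group or a plain amino group on the same nitrogen would keep it.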